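Trifluoromethyl on the pyridine ring: a tolerability estimate

The compounds below may be only part of what the source reports. "The series", "measured", "known", "first", "only" and "open" are said of these compounds alone.

Compound 1 `Cc1cnc(Nc2ccc(C#N)cc2)nc1Nc1c(F)cc(-c2cccnc2)cc1F` was examined in a toxicity assay on MT4 cells (Homo sapiens) for cytotoxicity, read by MTT assay, with a stated time of 5 days (a higher number here means that more compound is tolerated, a lower number that less compound is tolerated), and gave 1100 nM. Among the three measured compounds it stands lowest: compound 2 `Cc1cnc(Nc2ccc(C#N)cc2)nc1Nc1c(F)cc(-c2ccoc2)cc1F` gives 4200 nM, and compound 3 `Cc1cnc(Nc2ccc(C#N)cc2)nc1Nc1c(F)cc(-c2ccsc2)cc1F` gives 261000 nM. The measured steps are a 3.8-fold higher number from compound 1 to compound 2 (0.58 log units; beyond the scatter), a 240-fold higher number from compound 1 to compound 3 (2.38 log units; beyond the scatter) and a 62-fold higher number from compound 2 to compound 3 (1.79 log units; beyond the scatter); each exchanges the whole pyridin-3-yl or furan-3-yl ring for another ring, and each moves the number upward from compound 1.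

Compound 4 `Cc1cnc(Nc2ccc(C#N)cc2)nc1Nc1c(F)cc(-c2cncc(C(F)(F)F)c2)cc1F` differs from compound 1 by trifluoromethyl in place of hydrogen on an aromatic carbon, read one bond further out as pyridin-3-yl to 5-(trifluoromethyl)pyridin-3-yl. Going by the values given here, none of the measured steps adds a group to a retained ring, so they bear on this change only loosely; they show that every alteration at this ring so far raised the number in this assay, yet they give no step of the same kind. A modest rise beyond the scatter, with wide uncertainty, is the expectation for compound 4, whose number in this assay is estimated at 2500 nM, between 800 nM and 9000 nM, corresponding to an expected step of a 2.3-fold higher number from compound 1 to compound 4 (0.36 log units; beyond the scatter).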

Compound 4, half-maximal cytotoxic concentration: 8200 nM
The estimate for compound 4 lay 3.3-fold (0.52 log units) below the measured number; low and high end bracket the measured number.
By their numbers in this assay, from the lowest: compound 1; then compounds 2 and 4 (each within the scatter of the next); then compound 3.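

In this assay, the step that keeps the pyridine ring and only adds trifluoromethyl gives a 7.5-fold higher number from compound 1 to compound 4 (0.87 log units; beyond the scatter) and is the only step shown that adds a group to a retained ring, so a substituent at this place, two atoms from the ring nitrogen, moves the number without any exchange of ring. Against the ring exchanges, the substituted ring stands level with furan-3-yl, with a 2.0-fold higher number from compound 2 to compound 4 (0.29 log units; within the scatter) lying within the scatter, while thiophen-3-yl stays well apart, with a 32-fold lower number from compound 3 to compound 4 (1.50 log units; beyond the scatter) being a large step. Nothing measured here accounts for these steps.

Trifluoromethyl is the only substituent shown on this ring, so whether a methyl, a chlorine, an amine or a carboxylic acid at this place would move the number the same way stays open. Also open, as far as these compounds go, is what trifluoromethyl would do on the furan-3-yl or thiophen-3-yl ring.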